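A few compounds are considered here, and "the series" means these few. Any claim that something is new, unique, unknown or untested is made for them only; others in the source may bear on it.

In an assay for inhibition of Nicotinamide phosphoribosyltransferase (Mus musculus), read by fluorescence, with a stated time of 1 h, in the presence of a further agent that is not named here (on this read-out lower numbers stand for stronger inhibition and higher numbers for weaker inhibition), compound 1 `O=C(O)c1ccccc1-c1ccccc1C(=O)NCCCCCCCn1cc(-c2cccnc2)nn1` gives 38.5 nM, and compound 2 `O=C(NCCCCCCCn1cc(-c2cccnc2)nn1)c1ccccc1-c1cccnc1` gives 28.5 nM. Compound 2 holds the lowest of the two numbers shown, yet its gap to compound 1 lies within the scatter. For the measured compounds named here, the one measured step, a 1.4-fold lower number from compound 1 to compound 2 (0.13 log units; within the scatter), swapped a group on the same aromatic carbon that compound 3 `O=C(NCCCCCCCn1cc(-c2cccnc2)nn1)c1ccccc1-n1cc(CN2CCCCC2)nn1` alters again, with 4-((piperidin-1-yl)methyl)-1H-1,2,3-triazol-1-yl in place of pyridin-3-yl on an aromatic carbon. Because a 1.4-fold lower number from compound 1 to compound 2 (0.13 log units; within the scatter) stayed within the scatter, a step of a 1.4-fold higher number from compound 2 to compound 3 (0.15 log units; within the scatter) is expected, with no clear direction. Compound 3 is therefore estimated at 40 nM, in a range from 10 nM to 160 nM.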

Compound 3, half-maximal inhibitory concentration: 17.1 nM
The estimate for compound 3 lay 2.3-fold (0.37 log units) above the measured number; the range from low to high includes it.
By their numbers in this assay, from the lowest: compounds 3, 2 and 1 (each within the scatter of the next, the first and the last beyond it).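

At this aromatic carbon, the larger 4-((piperidin-1-yl)methyl)-1H-1,2,3-triazol-1-yl, with its non-aromatic ring, is accommodated in place of pyridin-3-yl in this assay, with a 1.7-fold lower number from compound 2 to compound 3 (0.22 log units; within the scatter). Set against 2-carboxyphenyl, the same group gives the first step at this position beyond the scatter, a 2.3-fold lower number from compound 1 to compound 3 (0.35 log units; beyond the scatter), though a modest one. Nothing measured here accounts for either step.

As far as these compounds go, whether the piperidine ring or the triazole matters more at this position stays open. So does how a morpholine or a dimethylamine in place of the piperidine would read.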